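The source may report more compounds than this note shows. Statements on the series, on what has been measured and on what is new or still open speak of the compounds shown alone.

Compound 1 `COc1cc2c(Oc3ccc(NC(=O)c4nn(-c5ccccc5)c(=O)c5ccccc45)cc3F)ccnc2cc1OCCCN1CCN(C)CC1` and compound 2 `COc1cc2c(Oc3ccc(NC(=O)c4nn(-c5ccccc5F)c(=O)c5ccccc45)cc3F)ccnc2cc1OCCCN1CCN(C)CC1` share one core and differ in a single place. In a functional assay on HT-29 cells (Homo sapiens) for cytotoxicity, read by MTT assay, with a stated time of 72 h (on this read-out higher numbers stand for weaker inhibition and lower numbers for stronger inhibition), compound 1 gives 1140 nM, and in the same assay compound 2 gives 480 nM. For the measured compounds named here, of the two numbers so far, compound 1 carries the higher one; the only measured step, a 2.4-fold lower number from compound 1 to compound 2 (0.38 log units; beyond the scatter), comes from a fluoro in place of hydrogen on an aromatic carbon. Compound 3 `COc1cc2c(Oc3ccc(NC(=O)c4nn(-c5ccccc5)c(=O)c5ccccc45)cc3F)ccnc2cc1OCCCN1CCC(C)CC1` has not yet been measured. It differs from compound 1 in a different part of the molecule: 4-methylpiperidin-1-yl in place of 4-methylpiperazin-1-yl on a saturated chain carbon, three bonds along the chain from an oxygen on an aromatic ring. Going by the values given here, no measured step touches this part of the structure, so the step from compound 1 to compound 2 says nothing about how the new ring will read. Among the compounds with values here, with no step to lean on, the expectation is that compound 3 stays near compound 1, with no step beyond the scatter in this assay but wide uncertainty in either direction. The expected step is no change at the digits printed from compound 1 to compound 3 (within the scatter). Compound 3 is therefore estimated at 1140 nM, within a range from 350 nM to 3700 nM.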

Compound 3, half-maximal inhibitory concentration: 1040 nM
Beside the measured number, compound 3's estimate is 1.1-fold (0.04 log units) above it; the measured number falls inside the stated range.
By their numbers in this assay, from the lowest: compound 2; then compounds 3 and 1 (each within the scatter of the next).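

In this assay, placing 4-methylpiperidin-1-yl where 4-methylpiperazin-1-yl stood, on a saturated chain carbon, three bonds along the chain from an oxygen on an aromatic ring, gives a 1.1-fold lower number from compound 1 to compound 3 (0.04 log units; within the scatter), so this assay does not separate the two rings, even though the entering ring holds 1 nitrogen rather than 2 and 1 hydrogen-bond acceptor rather than 2. For the compounds shown here, the earlier step, fluoro in place of hydrogen on an aromatic carbon, said nothing about this part of the molecule, and this pair is the first to show that, for these two rings on this core, the exchange leaves the reading within the usual scatter. No supporting evidence is available to explain this outcome.

The compounds shown leave open whether other groups in this position, such as morpholin-4-yl or dimethylamino, or a chain longer than the propyl, would read the same way. They also leave open whether the fluoro change that separates compound 2 from compound 1 would give a similar step when combined with the 4-methylpiperidin-1-yl group of compound 3.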